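Methyl in Place of Trifluoromethyl on the Benzyl Arm

The compounds below may be only part of what the source reports. "The series", "measured", "known", "first", "only" and "open" are said of these compounds alone.

Compound 1 `CC(C)Cn1c(=O)c2nc(-c3cnn(Cc4cccc(F)c4)c3)[nH]c2n(CC(C)C)c1=O`: 990 nM
Compound 2 `CCCn1c(=O)c2nc(-c3ccnn3-c3ccccc3)[nH]c2n(CCC)c1=O`: 1100 nM
Compound 3 `CCCn1c(=O)c2nc(-c3cnn(Cc4ccccc4C(F)(F)F)c3)[nH]c2n(CCC)c1=O`: 37 nM

Of the compounds shown here, three built on a shared core have been tested in an in vitro assay on HEK293 cells for displacement of a labelled ligand from adenosine receptor A2b (Homo sapiens); a higher number here means a weaker inhibitor, a lower number a stronger inhibitor. Compound 3 gives 37 nM, the lowest of the three numbers and so the strongest inhibitor among them. Compound 1 gives 990 nM and compound 2 gives 1100 nM; both gaps from compound 3 lie well beyond the usual scatter, so the ranking is firm.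

Compound 4 `CCCn1c(=O)c2nc(-c3cnn(Cc4ccccc4C)c3)[nH]c2n(CCC)c1=O` has not yet been measured. It differs from compound 3 in a single place: methyl in place of trifluoromethyl on an aromatic carbon. For the measured compounds named here, no pair of measured compounds shows this change on its own, so there is no directly comparable step to lean on; the expectation has to rest on the position of compound 3 alone.

The expected outcome is a modest weakening. The step of a 2.4-fold higher number from compound 3 to compound 4 (0.39 log units; beyond the scatter) is estimated to be a small rise in the inhibition constant, of a size that may not clear the scatter. Compound 4 is therefore estimated at 90 nM, with a likely range from 30 nM to 300 nM.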

Compound 4, inhibition constant: 33 nM
Compound 4: the middle estimate sits 2.7-fold (0.44 log units) above what was measured; the measured number falls inside the stated range.
By their numbers in this assay, from the lowest: compounds 4 and 3 (each within the scatter of the next); then compounds 1 and 2 (each within the scatter of the next).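

In this assay, putting methyl in place of trifluoromethyl on an aromatic carbon ortho to a large group gives a 1.1-fold lower number from compound 3 to compound 4 (0.05 log units; within the scatter), so the two compounds cannot be told apart. For the compounds shown here, this is the first direct view of this change, and it shows that the fluorine atoms of the 2-(trifluoromethyl)benzyl arm are not required: the simpler 2-methylbenzyl arm on the same core holds the value within the usual scatter of repeated measurements. Nothing shown here explains why these two groups give matching numbers.

On these data alone, it remains open whether this position accepts other groups equally well, such as a chlorine atom, a methoxy group or a nitrile, or whether plain hydrogen in place of the group would keep the value, which would show whether anything is needed there at all. Also open, as far as these compounds go, is whether methyl and trifluoromethyl would still match on a core carrying different chains, such as the branched chains of compound 1.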